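This account rests on a few compounds, and the source may have more. Where it says the series, first, only, none or still open, it means among the compounds named here.

Two compounds in this set have numbers in a functional assay on MCF7 cells (Homo sapiens) for cytotoxicity; on this read-out higher numbers stand for weaker inhibition and lower numbers for stronger inhibition. Compound 1 `CCC1C(=O)N(CCCCCCCOc2ccc(Cl)cc2)/C(=N\C#N)N1c1ccncc1` gives 4540 nM in this assay, and compound 2 `N#C/N=C1\N(CCCCCOc2ccc(Cl)cc2)C(=O)C(c2ccccc2)N1c1ccncc1` gives 1000 nM, the lower of the two numbers and the stronger of the pair, a gap beyond the usual scatter. Among the measured compounds shown here, these two compounds differ in more than one place, so no single step links them. Compound 3 `N#C/N=C1\N(CCCCCCCOc2ccc(Cl)cc2)C(=O)C(c2ccccc2)N1c1ccncc1` is the next to be measured. It differs from compound 2 in one place: 2-(4-chlorophenoxy)ethyl in place of 4-chlorophenoxy on a saturated chain carbon, five bonds along the chain from an amide-type nitrogen in a ring. For the measured compounds named here, no measured pair shows this change on its own. Compound 1 carries the same longer chain as compound 3 but also a different group on the ring, so its higher number cannot be laid to the chain alone. A modest step toward a higher number, or none beyond the scatter, is expected in this assay, a 1.5-fold higher number from compound 2 to compound 3 (0.18 log units; within the scatter). Compound 3 is estimated at 1500 nM, within a range from 500 nM to 5000 nM.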

Compound 3, half-maximal inhibitory concentration: 1170 nM
Estimate against measurement, compound 3: 1.3-fold (0.11 log units) above, within the range that was stated.
By their numbers in this assay, from the lowest: compounds 2 and 3 (each within the scatter of the next); then compound 1.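

In this assay, 2-(4-chlorophenoxy)ethyl in place of 4-chlorophenoxy on a saturated chain carbon, five bonds along the chain from an amide-type nitrogen in a ring, gives a 1.2-fold higher number from compound 2 to compound 3 (0.07 log units; within the scatter), so this extension leaves the read-out unchanged within the scatter. With that longer chain held the same, phenyl in place of ethyl on a saturated ring carbon gives a 3.9-fold lower number from compound 1 to compound 3 (0.59 log units; beyond the scatter), which places the gap beyond the scatter at the ring carbon rather than on the chain. No measurement here explains either step.

On these data alone, whether a still longer chain, or one shorter than that of compound 2, would hold the number remains open. So does the effect of an amine or a carboxylic acid in place of the 4-chlorophenoxy end, or of a benzyl group in place of phenyl on the ring carbon.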